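The compounds below may be only part of what the source reports. "The series", "measured", "known", "first", "only" and "open" are said of these compounds alone.

Measured so far in a functional assay on SW620/5-FU cells (Homo sapiens) for cytotoxicity, read by MTT assay, with a stated time of 48 h, in the presence of a further agent that is not named here; on this read-out lower numbers stand for an effect already at smaller amounts and higher numbers for an effect only at larger amounts of compound:
compound 1 `CCCc1cc(NNC(=O)Nc2cc(Cl)nc(Cl)c2)nc2c1c(C)nn2C`: 40800 nM
compound 2 `Cn1ncc2c(-c3ccc(F)cc3)cc(NNC(=O)Nc3cc(Cl)nc(OCCF)c3)nc21`: 29300 nM
compound 3 `CCCc1cc(NNC(=O)Nc2cc(Cl)nc(Cl)c2)nc2c1cnn2C`: 38700 nM

Compound 1 lies within the scatter of both other compounds, so the three values form a single level and no order can be read among them.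

The compound to be measured next is compound 4 `Cc1nn(C)c2nc(NNC(=O)Nc3cc(Cl)nc(Cl)c3)cc(-c3ccco3)c12`. It departs from compound 1 by one change, furan-2-yl in place of propyl on an aromatic carbon.

Among the compounds with values here, only one measured step bears on the series, and only indirectly: a 1.1-fold lower number from compound 1 to compound 3 (0.02 log units; within the scatter) is hydrogen in place of methyl on an aromatic carbon. That step stays within the scatter and leaves the propyl group untouched, so no measurement tests the exchange of propyl for furan-2-yl directly. Within the data shown here, no single-place step connects compound 2 to compound 1, and compound 2 at 29300 nM serves only to mark the same level.

With this little evidence, no step beyond the scatter is expected in this assay, and no direction can be argued with confidence. The expected step is a 1.3-fold lower number from compound 1 to compound 4 (0.11 log units; within the scatter) and remains within the scatter. Compound 4 is estimated at 32000 nM with an expected range from 16000 nM to 60000 nM as the working figure.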

Compound 4, half-maximal effective concentration: > 100000 nM
Compound 4: no number, only a limit; the forecaster's own chance of this, stated with the estimate: 10%; middle value at least 3.1-fold (0.49 log units) from the limit.
By their numbers in this assay, from the lowest: compounds 2, 3 and 1 (each within the scatter of the next). At a limit, above all of these: compound 4.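

Working notes on this position, opposite the ring nitrogen: it is the first place in the series where a single change moves the read-out beyond the scatter. In this assay, within the data shown here, furan-2-yl in place of propyl on an aromatic carbon gives an at least 2.4-fold higher number from compound 1 to compound 4 (0.38 log units; beyond the scatter), a shift towards an effect only at larger amounts of compound, whereas the one earlier step, at a different place, stayed within the scatter. Compound 4 stands at > 100000 nM, which is a limit of the assay and not a number, so the true size of the step stays unknown because the value sits at that limit: the limit of > 100000 nM in this assay, at which 1 of the 4 values shown sits.

The compounds shown do not separate the contribution of the ring from that of its oxygen, and a thiophen-2-yl or cyclopentyl group at this place would be needed to tell these apart. They also leave open whether a longer chain such as butyl, or an amine carried on the propyl chain, would keep the level of compound 1, and whether the same exchange would act alike on the core of compound 3, which lacks the methyl.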